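Adding a methyl to a compound at the assay limit

This account rests on a few compounds, and the source may have more. Where it says the series, first, only, none or still open, it means among the compounds named here.

Compound 1 `COc1cc(C#N)ccc1OCc1nnc(-c2ccc(Cl)cc2)o1` gives 21500 nM
Compound 2 `Cc1ccc(-c2nnc(COc3ccc(C#N)c(F)c3)o2)cc1` gives > 50000 nM (a limit)
Compound 3 `c1ccc(-c2nnc(COc3ccc(-c4nnco4)cc3)o2)cc1` gives > 50000 nM (a limit)

In a functional assay on MCF7 cells (Homo sapiens) for cytotoxicity, read by MTT assay, with a stated time of 48 h (on this read-out lower numbers stand for stronger inhibition and higher numbers for weaker inhibition), compound 3 gives > 50000 nM as its reading, which is a limit and not a number. Among the measured compounds shown here, compound 1 alone has a true number so far, 21500 nM in this test.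

Compound 4 `Cc1ccc(-c2nnc(COc3ccc(-c4nnco4)cc3)o2)cc1` differs from compound 3 by one small change, methyl in place of hydrogen on an aromatic carbon, which turns phenyl into 4-methylphenyl. Compound 2 also carries 4-methylphenyl and reads > 50000 nM as another limit. No change beyond the usual scatter is therefore expected in this assay for this swap. The expected step (an at least 1.1-fold lower number from compound 3 to compound 4 (0.04 log units; that floor lies within the scatter)) is small. For compound 4 the estimated value is 45000 nM with an expected range from 15000 nM to 80000 nM in this test.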

Compound 4, half-maximal inhibitory concentration: > 50000 nM
Compound 4 ended at the assay's limit; the forecaster's own chance of this, stated with the estimate: 65%; middle value at least 1.1-fold (0.04 log units) away from the limit.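

No step can be read between compound 3 and compound 4, since both readings are limits and not numbers: the limit of > 50000 nM in this assay, at which 3 of the 4 values shown sit.

On these data alone, whether going from phenyl to 4-methylphenyl changes the reading at all stays open.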